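Chain Extension in a Diyne Alcohol Series

A few compounds are considered here, and "the series" means these few. Any claim that something is new, unique, unknown or untested is made for them only; others in the source may bear on it.

Among the compounds with values here, compound 2 `C=CCCCCCC#CC#CC(O)CC(C)=O` is the lower of the two numbers so far in a functional assay on SK-OV-3 cells (Homo sapiens) for cytotoxicity; on this read-out lower numbers stand for an effect already at smaller amounts and higher numbers for an effect only at larger amounts of compound. In this assay, within the data shown here, compound 2 gives 3.85 ug/mL, whereas compound 1 `C=CCCCCCC#CC#CCO` gives 9.79 ug/mL; the one measured step, a 2.5-fold lower number from compound 1 to compound 2 (0.41 log units; beyond the scatter), introduced the ketone-bearing side chain. Compound 3 `C=CCCCCCCCC#CC#CC(O)CC(C)=O` differs from compound 2 by but-3-en-1-yl in place of vinyl on a saturated chain carbon, five bonds along the chain from a triple-bonded carbon. Among the measured compounds shown here, no measured step touches this part of the molecule: the only change recorded so far lies at the carbon bound to oxygen, not along the terminal alkenyl chain, so nothing among the measured compounds speaks for a shift in either direction. The step of a 1.0-fold lower number from compound 2 to compound 3 (0.01 log units; within the scatter) is therefore expected to remain within the usual scatter. Compound 3 is estimated to give about 3.8 ug/mL in this assay, with a range from 1.6 ug/mL to 9 ug/mL.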

Compound 3, concentration for half-maximal effect: 3.34 ug/mL
Beside the measured number, compound 3's estimate is 1.1-fold (0.06 log units) above it, within the range that was stated.
By their numbers in this assay, from the lowest: compounds 3 and 2 (each within the scatter of the next); then compound 1.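

Within the data shown here, replacing vinyl with but-3-en-1-yl on a saturated chain carbon, five bonds along the chain from a triple-bonded carbon, gave a 1.2-fold lower number from compound 2 to compound 3 (0.06 log units; within the scatter) in this assay, the first measured reading of a change along the terminal alkenyl chain. Among these compounds, at this position, the longer chain left the number within the scatter, while a 2.5-fold lower number from compound 1 to compound 2 (0.41 log units; beyond the scatter), at the carbon bound to oxygen, remains the only step that lies beyond it. No measurement shown here offers an explanation for this result.

The compounds shown leave open whether the terminal double bond matters at all, since all three carry it, and how this position would respond to a much longer alkenyl chain, a carboxylic acid or an amine at the chain end. They also leave open whether the 2-oxopropyl step would have the same size on the but-3-en-1-yl chain.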